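Compound 2 and a different placement of its chlorine

The source may hold more compounds than are shown below. What is called first, only, known or untested is meant among the compounds shown, and "the series" means these compounds.

Compound 1 `CCCCC#Cc1cc([C@@H]2O[C@H](CO)[C@@H](O)[C@H]2O)n2ncnc(N)c12` gives 2400 nM in a functional assay on K562 cells (Homo sapiens) for antiproliferative activity, with a stated time of 72 h; on this read-out lower numbers stand for stronger inhibition and higher numbers for weaker inhibition. For the measured compounds named here, compound 2 `Nc1ncnn2c([C@@H]3O[C@H](CO)[C@@H](O)[C@H]3O)cc(-c3ccc(Cl)cc3)c12` gives 47800 nM in this assay, the highest of the two numbers measured so far; the only measured step is a 20-fold higher number from compound 1 to compound 2 (1.30 log units; beyond the scatter). Compound 3 `Nc1ncnn2c([C@@H]3O[C@H](CO)[C@@H](O)[C@H]3O)cc(-c3ccccc3Cl)c12` differs from compound 2 in one place: 2-chlorophenyl in place of 4-chlorophenyl on an aromatic carbon. Going by the values given here, that measured step replaced the whole group on this carbon, not the position of the chlorine within it, so no measured step bears directly on the present change, and no step beyond the scatter is expected. Compound 3 is therefore expected at 40000 nM, ranging from 14000 nM to 110000 nM. The expected step is a 1.2-fold lower number from compound 2 to compound 3 (0.08 log units; within the scatter).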

Compound 3, half-maximal inhibitory concentration: > 100000 nM
Compound 3: a limit, no number; the forecaster's own chance of this, stated with the estimate: 15%; middle value at least 2.5-fold (0.39 log units) from the limit.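

Compound 3 is recorded as a limit, not a number: the limit of > 100000 nM in this assay, at which 1 of the 3 values shown sits.

Even so, the place of the chlorine on the phenyl ring matters at this position, although the atoms stay the same, giving an at least 2.0-fold higher number from compound 2 to compound 3 (0.32 log units; beyond the scatter). With 2-chlorophenyl in place of hex-1-yn-1-yl, the gap is wider still, at an at least 41-fold higher number from compound 1 to compound 3 (1.61 log units; beyond the scatter).

The compounds shown leave open how this carbon would respond to a plain phenyl, a shorter alkyne chain or an amine. They also leave open whether the chlorine or the phenyl ring itself accounts for most of the gap to compound 1.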